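The source may report more compounds than this note shows. Statements on the series, on what has been measured and on what is new or still open speak of the compounds shown alone.

Among the measured compounds shown here, compound 2 `O=c1[nH]c(=O)n([C@H]2C[C@H](O)[C@@H](CO)O2)cc1-c1cn(-c2cc(F)cc(F)c2)nn1` is the only compound with a plain number here: in an ADME assay on HEL cells (Homo sapiens) for cytotoxicity, read by cell counting, with a stated time of 3 days (on this read-out higher numbers stand for lower toxicity in this test and lower numbers for higher toxicity in this test), compound 2 gives 220000 nM. Compound 1 `O=c1[nH]c(=O)n([C@H]2C[C@H](O)[C@@H](CO)O2)cc1-c1cn(-c2c(F)cccc2F)nn1` stands at a limit of the test, >= 10000 nM, rather than at a number. For the measured compounds named here, the single measured step, a step that the limit leaves unreadable from compound 1 to compound 2, therefore cannot be sized, because of the limit of >= 10000 nM in this assay, at which 1 of the 2 values shown sits. Compound 3 `CC(C)c1ccc(-n2cc(-c3cn([C@H]4C[C@H](O)[C@@H](CO)O4)c(=O)[nH]c3=O)nn2)cc1` differs from compound 2 by 4-isopropylphenyl in place of 3,5-difluorophenyl on an aromatic nitrogen. Going by the values given here, no measured step bears on this change, so no direction beyond the scatter is expected, and compound 3 is estimated near compound 2 with a step of a 1.5-fold lower number from compound 2 to compound 3 (0.17 log units; within the scatter). Compound 3 is expected to give about 150000 nM, within 30000 nM to 400000 nM.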

Compound 3, minimum cytotoxic concentration: > 240000 nM
Compound 3: only a limit was reported; the forecaster's own chance of this, stated with the estimate: 35%; middle value at least 1.6-fold (0.20 log units) away from the limit.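

In this assay compound 3 gives > 240000 nM, which is a limit of the test and not a number. Placing 4-isopropylphenyl instead of 3,5-difluorophenyl on the aromatic nitrogen gives an at least 1.0-fold higher number from compound 2 to compound 3 (0.03 log units; that floor lies within the scatter), so this change shows no sign of higher toxicity in this test, and the size of any real difference stays unknown. The step involving compound 1 cannot be read: the limit of >= 10000 nM in this assay, at which 1 of the 3 values shown sits.

On these data alone, how far compound 3 truly lies from its limit remains open. So does what an amine or a carboxylic acid on this phenyl ring would do to the read-out.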